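A few compounds are considered here, and "the series" means these few. Any claim that something is new, unique, unknown or untested is made for them only; others in the source may bear on it.

In an ADME assay on the whole organism for inhibition, with Oryza sativa as the target, with a stated time of 4 days (a lower number here means a stronger inhibitor, a higher number a weaker inhibitor), three compounds sharing one core and differing in the group on one ring-bound nitrogen have been measured. Compound 1 `CC[C@H](C)Nc1nc(Cl)nc(N[C@@H](C)c2ccccc2)n1`, with sec-butyl, gives 6920 nM. Compound 2 `CC(C)Nc1nc(Cl)nc(N[C@@H](C)c2ccccc2)n1`, with isopropyl, gives 23400 nM, and compound 3 `CCCCNc1nc(Cl)nc(N[C@@H](C)c2ccccc2)n1`, with butyl, gives 23400 nM. Compound 3 therefore stands level with compound 2, and both numbers lie above that of compound 1. The measured steps are a 3.4-fold higher number from compound 1 to compound 3 (0.53 log units; beyond the scatter), a 3.4-fold higher number from compound 1 to compound 2 (0.53 log units; beyond the scatter) and no change at the digits printed from compound 2 to compound 3 (within the scatter).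

Compound 4 `CCCN(C)c1nc(Cl)nc(N[C@@H](C)c2ccccc2)n1` has the same atoms as compound 3, joined differently, with methyl(propyl)amino in place of butylamino on an aromatic carbon. For the measured compounds named here, none of the measured compounds lacks the hydrogen on that nitrogen, so no measured step tests this change directly. The steps among the measured chains offer only a rough guide to size, the largest being a 3.4-fold higher number from compound 1 to compound 3 (0.53 log units; beyond the scatter). A modest move towards a higher number in this assay is expected on that guide, although a result within the scatter would not be surprising. The expected step, an estimate only, is a 1.7-fold higher number from compound 3 to compound 4 (0.23 log units; within the scatter). For compound 4 the estimated value is 40000 nM, with an expected range from 14000 nM to 110000 nM.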

Compound 4, half-maximal inhibitory concentration: 5500 nM
For compound 4 the middle estimate is 7.3-fold (0.86 log units) above the measured one; measured number below the stated range.
By their numbers in this assay, from the lowest: compounds 4 and 1 (each within the scatter of the next); then compounds 2 and 3 (each within the scatter of the next).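

In this assay, for the compounds shown here, the same atoms rearranged from butylamino to methyl(propyl)amino give a 4.3-fold lower number from compound 3 to compound 4 (0.63 log units; beyond the scatter) and so show that this position responds to how the atoms are joined, which the earlier compounds, with their different chains, could not show. Set against the isopropylamino group, the methyl(propyl)amino group gives a 4.3-fold lower number from compound 2 to compound 4 (0.63 log units; beyond the scatter) and thus a step of similar size, whereas against the (sec-butyl)amino group it gives a 1.3-fold lower number from compound 1 to compound 4 (0.10 log units; within the scatter) and the two compounds cannot be told apart. Going by these compounds alone, all three earlier compounds keep the hydrogen on this nitrogen, so compound 4 is the first to show that the hydrogen can be absent while the number stays as low as the lowest seen before.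

Nothing shown gives a reason for these steps. On these data alone, whether the loss of that hydrogen or the new branching at the nitrogen accounts for the step stays open, as does how a dimethylamino, diethylamino, methyl(butyl)amino or pyrrolidinyl group would read at this position.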